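The source may hold more compounds than are shown below. What is called first, only, known or untested is meant among the compounds shown, and "the series" means these compounds.

In a physicochemical assay for solubility, in phosphate buffer, at pH 7.4 (a lower number here means a less soluble compound, a higher number a more soluble compound), compound 1 (`COCC1CCN(c2nccnc2OC2CN(c3ccc4ccccc4n3)C2)CC1`) gives 53000 nM and compound 2 (`NC(=O)C1CCN(c2nccnc2OC2CN(c3ccc4ccccc4n3)C2)CC1`) gives 14000 nM, while compound 3 (`c1ccc2nc(N3CC(Oc4nccnc4-c4cncnc4)C3)ccc2c1`) stands highest of the three at 254000 nM on these numbers. The change now in question leads from compound 3 to compound 4 (`Cc1ncccc1-c1nccnc1OC1CN(c2ccc3ccccc3n2)C1`), with 2-methylpyridin-3-yl in place of pyrimidin-5-yl on an aromatic carbon, next to the ring nitrogen and ortho to a large group (2-methylpyridin-3-yl in place of pyrimidin-5-yl on an aromatic carbon). Among the compounds with values here, two measured steps concern that same aromatic carbon. The step of a 4.8-fold higher number from compound 1 to compound 3 (0.68 log units; beyond the scatter) is modest, and the step of an 18-fold higher number from compound 2 to compound 3 (1.26 log units; beyond the scatter) is large. Within the data shown here, both bring in the pyrimidin-5-yl group in place of a substituted piperidine, so neither exchanges one aromatic ring for another, and the data hold no direct precedent for this change. The remaining step of a 3.8-fold lower number from compound 1 to compound 2 (0.58 log units; beyond the scatter) lies on a saturated ring carbon and bears on it less. With compound 3 at the top of this small set, and its nearest neighbour set by the modest step of a 4.8-fold higher number from compound 1 to compound 3 (0.68 log units; beyond the scatter) as the closest guide, a modest fall is expected. The estimated step is a 2.3-fold lower number from compound 3 to compound 4 (0.36 log units; beyond the scatter) in this assay as a lower number. The expected value for compound 4 is 110000 nM with an estimated range of 35000 nM to 280000 nM around it.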

Compound 4, solubility: 253000 nM
Beside the measured number, compound 4's estimate is 2.3-fold (0.36 log units) below it; the measured number falls inside the stated range.
By their numbers in this assay, from the lowest: compound 2; then compound 1; then compounds 4 and 3 (each within the scatter of the next).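

In this assay, within the data shown here, the exchange of pyrimidin-5-yl for 2-methylpyridin-3-yl gives a 1.0-fold lower number from compound 3 to compound 4 (0.00 log units; within the scatter) at this aromatic carbon, the first step here that swaps one aromatic ring for another, even though the count moves from 6 heavy atoms to 7 and from 2 hydrogen-bond acceptors to 1. The rise over the piperidine compounds is therefore not confined to pyrimidin-5-yl, for the new group also gives an 18-fold higher number from compound 2 to compound 4 (1.26 log units; beyond the scatter) and a 4.8-fold higher number from compound 1 to compound 4 (0.68 log units; beyond the scatter) in the same assay, steps that match in size those printed for compound 3. Nothing measured here accounts for why the two aromatic groups stand level.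

The compounds shown leave open whether a phenyl ring, with no hetero atom, or a 2-aminopyridin-3-yl group on this aromatic carbon would stay level with compound 3 and compound 4 or drop toward compound 1 and compound 2. They also cannot separate the added methyl from the change in ring nitrogens, since the step from pyrimidin-5-yl to 2-methylpyridin-3-yl alters both at once.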